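A few compounds are considered here, and "the series" means these few. Any claim that something is new, unique, unknown or untested is made for them only; others in the source may bear on it.

Measured compounds:
Compound 1, `ClCc1c[se]c(N/N=C/c2ccc(Cl)cc2)n1` — in a functional assay on HepG2 cells (Homo sapiens) for cytotoxicity, read by XTT assay, with a stated time of 72 h (on this read-out higher numbers stand for weaker inhibition and lower numbers for stronger inhibition), compound 1 gives > 75000 nM, which is a limit of the assay and not a number.
Compound 2, `CC(=O)N(/N=C/c1ccc(Cl)cc1)c1nc(C)c[se]1` — in this assay compound 2 gives 59200 nM.

Going by the values given here, compound 2 holds the only number among the values shown; the other value, that of compound 1, is a limit, so compound 2 cannot be placed against it in order. Among the compounds with values here, no step between measured compounds that differ in one place is available, and the two measured compounds differ in more than one place, so their values are reported side by side and nothing more.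

Compound 3, `CC(=O)N(/N=C/c1ccc(Cl)cc1)c1nc(CCl)c[se]1`, differs from compound 2 by chloro in place of hydrogen on a saturated chain carbon bound to an aromatic carbon, or, read one bond further out, methyl to chloromethyl. Compound 1 also carries a chloromethyl group and sits at the limit of > 75000 nM in this assay, at which 1 of the 2 values shown sits, but compound 1 is not a one-place neighbour of compound 2.

The step from compound 2 to compound 3 is expected to be a 1.1-fold higher number from compound 2 to compound 3 (0.04 log units; within the scatter), within the scatter or a modest weakening. Compound 3 is therefore estimated at 65000 nM, with a range from 25000 nM to 150000 nM.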

Compound 3, half-maximal inhibitory concentration: > 66600 nM
Compound 3 gave a limit, no number (the forecaster's own chance of this, stated with the estimate: 40%); middle value at least 1.0-fold (0.01 log units) from the limit.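

In this assay compound 3 gives a limit of the assay and not a number: the limit of > 66600 nM in this assay, at which 1 of the 3 values shown sits.
The swap of methyl to chloromethyl, with chloro in place of hydrogen on a saturated chain carbon bound to an aromatic carbon, now has a one-place reading, which compound 1 and compound 2 could not offer: the result is an at least 1.1-fold higher number from compound 2 to compound 3 (0.05 log units; that floor lies within the scatter), so this floor shows no change beyond the scatter, though the true size of the step may be larger. Compound 1 and compound 3, which both carry chloromethyl, stand at limits, and the step between them, acetyl in place of hydrogen on a nitrogen on an aromatic ring, cannot be read.

The compounds shown leave open whether a number for compound 3 would lie close to its limit or far from it, and so how large the step from methyl to chloromethyl really is. Also open, as far as these compounds go, is whether a hydroxymethyl group, an aminomethyl group or a longer chain such as ethyl in that place would give a number in this assay at all.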